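A few compounds are considered here, and "the series" means these few. Any claim that something is new, unique, unknown or untested is made for them only; others in the source may bear on it.

Measured compounds:
compound 1, `O=C(N/N=C/c1ccccc1O)c1cnccn1`, gives 0.3% in an ADME assay on J774 cells (Mus musculus) for cytotoxicity, read by MTT assay, with a stated time of 48 h, tested at 100 ug/mL; on this read-out higher numbers stand for a weaker effect at the one concentration tested and lower numbers for a stronger effect;
compound 2, `O=C(N/N=C/c1cccc(O)c1)c1cnccn1`, gives 100% in this assay;
compound 3, `N#Cc1ccccc1/C=N/NC(=O)c1cnccn1`, gives 75% in this assay.

Compound 2 stands highest of the three, above compound 3 and far above compound 1. Compound 1 and compound 2 share the same atoms joined differently; the difference between the two cores is not broken down here. From compound 1 to compound 3 the change is cyano in place of hydroxy on an aromatic carbon and it brought a number 74.7 percentage points higher from compound 1 to compound 3 (beyond the scatter).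

Compound 4, `N#Cc1cccc(/C=N/NC(=O)c2cnccn2)c1`, is not yet measured in this assay. It differs from compound 2 by cyano in place of hydroxy on an aromatic carbon. Among the measured compounds shown here, this is the same kind of change as the one from compound 1 to compound 3, but the place differs: there the cyano sits ortho to a large group, here meta to a large group.

The earlier step went strongly upward, yet compound 2 already gives 100%, so little room remains. He expects for compound 4 a step of a number 5 percentage points lower from compound 2 to compound 4 (within the scatter), because compound 2 sits at 100%. His estimate for compound 4 is 95%, between 72% and 100%.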

Compound 4, a percentage reported as activity, at one concentration (the size of the read-out at that concentration, not a potency): 100%
Beside the measured number, compound 4's estimate is 5 percentage points below it, within the range that was stated.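

On the core of compound 2, with the cyano meta to a large group, the swap of hydroxy for cyano gave no change at the digits printed from compound 2 to compound 4 (within the scatter). Set beside the step on the core of compound 1, the same swap did not carry over from one core to the other in this assay: the same change on two cores in this assay, a number 74.7 percentage points higher (beyond the scatter) from compound 1 to compound 3 and no change at the digits printed (within the scatter) from compound 2 to compound 4, 74.7 percentage points apart, beyond the scatter of two such steps

So, in this series, the size of the step seen on one core cannot be taken as a guide to its size on the other, although two steps are too few to show why they part or how the change would behave on any further core. The compounds shown leave open what other groups would do in the place of the hydroxy on either core, for instance an amine or a carboxylic acid. They also leave open whether the cyano would give a similar result at any other place on the same ring.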